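A few compounds are considered here, and "the series" means these few. Any claim that something is new, unique, unknown or untested is made for them only; others in the source may bear on it.

Among the compounds with values here, compound 3, with the structure `CN(Cc1ccc(C#N)cc1)Cc1ccc(COc2ccc3ccc(=O)oc3c2)cc1`, is one of three compounds measured in an assay for inhibition of Amine oxidase [flavin-containing] A (Rattus norvegicus), read by spectrophotometry, tested at 10 uM (on this read-out higher numbers stand for more inhibition at the one concentration tested (going by the name of the read-out) and lower numbers for less inhibition), where compound 3 gives 6%. Compound 1, `CN(C)Cc1ccc(COc2ccc3ccc(=O)oc3c2)cc1`, gives 17% in this assay, and compound 2, `Cc1cc2ccc(OCc3ccc(CN(C)Cc4cccc(Cl)c4)cc3)cc2oc1=O`, gives 0%. Within the data shown here, compound 3 therefore stands second highest of the three, within the scatter of compound 2 and separated from compound 1 by a step beyond the scatter, namely a number 11 percentage points lower from compound 1 to compound 3 (beyond the scatter), the only single-place step among the measured compounds.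

Compound 4, `Cc1cc2ccc(OCc3ccc(CN(C)Cc4ccc(C#N)cc4)cc3)cc2oc1=O`, is not yet measured. It differs from compound 3 by methyl in place of hydrogen on an aromatic carbon. Among the measured compounds shown here, no measured pair isolates this change: compound 2 carries the same methyl on its core, but it also differs from compound 3 in the group on the amine nitrogen. For the measured compounds named here, the value of compound 2, 0%, shows only that a methyl-bearing analogue can sit at the low end. Going by the values given here, the one measured step, a number 11 percentage points lower from compound 1 to compound 3 (beyond the scatter), concerns a different position and does not bear on the methyl. The expectation is therefore a change of a number 2 percentage points lower from compound 3 to compound 4 (within the scatter), which is not beyond the scatter. Compound 4 is estimated at 4% in this assay, with a range from 0% to 15%.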

Compound 4, a percentage reported as inhibition, at one concentration (the size of the read-out at that concentration, not a potency): 15%
Compound 4: middle estimate off by 11 percentage points, on the low side; the range from low to high includes it.
By their numbers in this assay, from the lowest: compounds 2, 3, 4 and 1 (each within the scatter of the next, the first and the last beyond it).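

Within the data shown here, for the first time, a pair of compounds isolates the methyl in place of hydrogen on an aromatic carbon, two atoms from the ring oxygen: in this assay this change gives a number 9 percentage points higher from compound 3 to compound 4 (within the scatter), so with the 4-cyanophenyl group held in place, the methyl at this position does not move the number beyond the scatter. With the methyl present in both compounds, 4-cyanophenyl in place of 3-chlorophenyl on a saturated chain carbon bound to an amine nitrogen gives a number 15 percentage points higher from compound 2 to compound 4 (beyond the scatter), a modest step showing that a methyl-bearing compound need not sit at the low end and that the group on the amine nitrogen still matters on this core. Nothing available here accounts for either step.

The compounds shown leave open whether the methyl would give a similar result on the dimethylamino compound 1 or on a compound carrying 3-chlorophenyl without the methyl. They also leave open how an ethyl or a methoxy group in place of the methyl at this aromatic carbon would read in this assay.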